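This account rests on a few compounds, and the source may have more. Where it says the series, first, only, none or still open, it means among the compounds named here.

The series shares one core, carried by compound 1 `CN1CCC[C@@H]1Cn1nc(Cc2cccc(Cl)c2)c2ccccc2c1=O`, compound 2 `CN1CCC[C@@H]1Cn1nc(Cc2ccc(F)c(F)c2)c2ccccc2c1=O` and compound 3 `COc1ccc(Cc2nn(C[C@H]3CCCN3C)c(=O)c3ccccc23)cc1OC`; the three differ only in the substituted phenyl ring. In an assay for binding affinity to Alpha-1B adrenergic receptor (Homo sapiens) (on this read-out lower numbers stand for stronger inhibition and higher numbers for weaker inhibition), compound 1 gives 631 nM. In this assay, going by the values given here, compound 2 gives 316 nM, and the step of a 2.0-fold lower number from compound 1 to compound 2 (0.30 log units; within the scatter) is the single measured one-place change. For compound 3 the readout in this assay is a limit, > 1990 nM, so compound 3 stands apart from the two halogenated compounds (the limit of > 1990 nM in this assay, at which 1 of the 3 values shown sits). Compound 4 `COc1cccc(Cc2nn(C[C@H]3CCCN3C)c(=O)c3ccccc23)c1` is not yet measured; it differs from compound 3 by hydrogen in place of methoxy on an aromatic carbon. Among the compounds with values here, no measured step involves a methoxy group, and the step of a 2.0-fold lower number from compound 1 to compound 2 (0.30 log units; within the scatter) between two halogenated rings does not bear on this change. Compound 1 and compound 2 carry small halogens on the same ring and give numbers inside the scale, whereas compound 3 with two methoxy groups sits at the limit. For compound 4 the number in this assay is expected to move toward the halogenated compounds, an estimated 1500 nM within 500 nM to 5000 nM, meaning an expected step of an at least 1.3-fold lower number from compound 3 to compound 4 (0.12 log units; that floor lies within the scatter).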

Compound 4, inhibition constant: > 1990 nM
Compound 4 was reported as a limit; the forecaster's own chance of this, stated with the estimate: 40%; middle value at least 1.3-fold (0.12 log units) from the limit.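

In this assay compound 4, with one methoxy group left on the ring, is again reported only as a limit, like compound 3: the limit of > 1990 nM in this assay, at which 2 of the 4 values shown sit.

The methoxy-bearing ring can now be set against the halogenated rings: methoxy in place of chloro gives an at least 3.1-fold higher number from compound 1 to compound 4 (0.49 log units; beyond the scatter), and 3-methoxyphenyl in place of 3,4-difluorophenyl gives an at least 6.2-fold higher number from compound 2 to compound 4 (0.79 log units; beyond the scatter). Both steps lie beyond the scatter, so a single methoxy group goes with the higher numbers in these two pairs, while the step between compound 3 and compound 4 cannot be read, as both values are limits.

Going by these compounds, what the second methoxy group contributes therefore stays open. Also open, on these data alone, is whether a hydroxyl group or an amine on that aromatic carbon would give a number inside the scale.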